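Shifting the Methoxy Pattern on the Benzyl Ether

The compounds below may be only part of what the source reports. "The series", "measured", "known", "first", "only" and "open" are said of these compounds alone.

Compound 3 `COc1ccc(COc2ccc(-c3cc(CN4CCN(Cc5ccc(C(F)(F)F)cc5)CC4)no3)cc2)cc1` gives 1300 nM in a functional assay on MCF7 cells (Homo sapiens) for antiproliferative activity, read by sulforhodamine B assay, with a stated time of 72 h (a higher number here means a weaker inhibitor, a lower number a stronger inhibitor), the lowest of the three numbers recorded so far. Compound 1 `Cc1cc(C)cc(COc2ccc(-c3cc(CN4CCN(Cc5ccc(C(F)(F)F)cc5)CC4)no3)cc2)c1` gives 1600 nM in this assay, and these two values lie within the scatter of each other. Compound 2 `FC(F)(F)c1ccc(CN2CCN(Cc3cc(-c4ccc(OCc5ccc(Cl)cc5)cc4)on3)CC2)cc1` gives 6700 nM in this assay. The step of a 5.2-fold lower number from compound 2 to compound 3 (0.71 log units; beyond the scatter) is beyond the scatter, as is a 4.2-fold higher number from compound 1 to compound 2 (0.62 log units; beyond the scatter), whereas a 1.2-fold lower number from compound 1 to compound 3 (0.09 log units; within the scatter) is not.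

Compound 4 `COc1cc(COc2ccc(-c3cc(CN4CCN(Cc5ccc(C(F)(F)F)cc5)CC4)no3)cc2)cc(OC)c1` differs from compound 3 in one place: 3,5-dimethoxyphenyl in place of 4-methoxyphenyl on a saturated chain carbon bound to an oxygen on an aromatic ring. Going by the values given here, two measured steps bear on this change. The step of a 1.2-fold lower number from compound 1 to compound 3 (0.09 log units; within the scatter) compares a 3,5-dimethylphenyl with a 4-methoxyphenyl on the same saturated chain carbon and stayed within the scatter, which suggests that a 3,5-disubstituted ring and a 4-substituted ring can give similar numbers here. The step of a 5.2-fold lower number from compound 2 to compound 3 (0.71 log units; beyond the scatter) shows that methoxy in place of chloro on that ring moved the number modestly. Among the compounds with values here, no measured compound carries a 3,5-dimethoxyphenyl, so the estimate rests on these two steps alone. Compound 4 is therefore expected to give 1800 nM in this assay, with a range from 800 nM to 4000 nM. The expected step is a 1.4-fold higher number from compound 3 to compound 4 (0.14 log units; within the scatter), which would not stand beyond the scatter.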

Compound 4, half-maximal inhibitory concentration: 100 nM
For compound 4 the middle estimate is 18-fold (1.26 log units) above the measured one; measured number below the stated range.
By their numbers in this assay, from the lowest: compound 4; then compounds 3 and 1 (each within the scatter of the next); then compound 2.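

Going by these compounds alone, this position tolerates far more change than the earlier compounds showed: in this assay, the 3,5-dimethoxyphenyl group gives a 13-fold lower number from compound 3 to compound 4 (1.11 log units; beyond the scatter), as well as a 16-fold lower number from compound 1 to compound 4 (1.20 log units; beyond the scatter) and a 67-fold lower number from compound 2 to compound 4 (1.83 log units; beyond the scatter), each a large step beyond the scatter and each larger than any step among the earlier compounds. The step from the 3,5-dimethylphenyl group matters most, since the two rings carry their substituents at the same printed positions, so that arrangement alone does not account for the lower number, and the single methoxy of the 4-methoxyphenyl group in compound 3 does not produce it either. Nothing available here explains why this particular group stands apart.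

The compounds shown leave open whether both methoxy groups are needed, as a 3-methoxyphenyl group would test, and whether the lower number extends to a 3,4,5-trimethoxyphenyl or a 3,5-diethoxyphenyl group. They also leave open whether the gain survives changes elsewhere in the molecule, such as a nitrile in place of the trifluoromethyl group.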